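From piperazin-1-yl to dimethylamino in compound 4

The source may report more compounds than this note shows. Statements on the series, on what has been measured and on what is new or still open speak of the compounds shown alone.

Measured in a toxicity assay on L02 cells (Homo sapiens) for cytotoxicity, read by MTT assay, with a stated time of 72 h; on this read-out higher numbers stand for weaker inhibition and lower numbers for stronger inhibition:
- compound 1 `CC1(C)OCC(Cn2cc(Cn3c4c(c5ccccc53)C(=O)c3c[n+]([O-])c5ccccc5c3C4=O)nn2)O1`: 120 nM
- compound 2 `O=C1c2c[n+]([O-])c3ccccc3c2C(=O)c2c1c1ccccc1n2CCCCN1CCNCC1`: 1380 nM
- compound 3 `CC1(C)OC[C@H](Cn2cc(Cn3c4c(c5ccccc53)C(=O)c3c[n+]([O-])c5ccccc5c3C4=O)nn2)O1`: 470 nM

Of these three, compound 2 has the highest number, 1380 nM, and compound 3 stands nearest to it. Compound 4 `CN(C)CCCCn1c2c(c3ccccc31)C(=O)c1c[n+]([O-])c3ccccc3c1C2=O` carries dimethylamino in place of piperazin-1-yl on a saturated chain carbon, four bonds along the chain from an aromatic nitrogen. Within the data shown here, the only measured step, a 3.9-fold higher number from compound 1 to compound 3 (0.59 log units; beyond the scatter), comes with the fact that one of compounds 1 and 3 is drawn with a defined configuration and the other without, at the place where they differ and leaves this chain untouched, so it shows only how far this assay can move and sets no direction. With compound 2 at 1380 nM, only a slight lean towards a lower number is expected. The expected change is a 1.5-fold lower number from compound 2 to compound 4 (0.19 log units; within the scatter), which stays within the scatter. For compound 4 the estimated value is 900 nM, with an expected range of 250 nM to 3000 nM.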

Compound 4, half-maximal inhibitory concentration: 300 nM
For compound 4 the middle estimate is 3.0-fold (0.48 log units) above the measured one; low and high end bracket the measured number.
By their numbers in this assay, from the lowest: compound 1; then compounds 4 and 3 (each within the scatter of the next); then compound 2.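

In this assay, replacing piperazin-1-yl with dimethylamino on a saturated chain carbon, four bonds along the chain from an aromatic nitrogen, gives a 4.6-fold lower number from compound 2 to compound 4 (0.66 log units; beyond the scatter) and is the first step shown at this position. It shows that this position can move the read-out beyond the scatter, with the ringless group giving the lower number. Nothing among the evidence given bears on why. As far as these compounds go, it remains open whether a morpholine ring or diethylamino at this place would follow dimethylamino or piperazin-1-yl. From the compounds shown here alone, how dimethylamino would behave on a shorter or longer chain also remains open.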